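A few compounds are considered here, and "the series" means these few. Any claim that something is new, unique, unknown or untested is made for them only; others in the source may bear on it.

Compound 1 `Cc1ccccc1NNC(=O)c1cccc(NS(=O)(=O)c2cnc(O)nc2O)c1`: > 20000 nM (a limit)
Compound 2 `O=C(NNc1ccccc1F)c1cccc(NS(=O)(=O)c2cnc(O)nc2O)c1`: > 20000 nM (a limit)
Compound 3 `Cc1ccccc1C(=O)NNC(=O)c1cccc(NS(=O)(=O)c2cnc(O)nc2O)c1`: 18100 nM

All three were tested in a functional assay on MDA-MB-231 cells (Homo sapiens) for antiproliferative activity, read by MTT assay, with a stated time of 24 h; a lower number here means a stronger inhibitor, a higher number a weaker inhibitor. Among the compounds with values here, there, compound 3 gives 18100 nM, the only true number in the set. The remaining evidence is the limit of > 20000 nM in this assay, at which 2 of the 3 values shown sit.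

Compound 4 `O=C(NNC(=O)c1cccc(NS(=O)(=O)c2cnc(O)nc2O)c1)c1ccc(F)cc1` differs from compound 3 in one place: 4-fluorophenyl in place of 2-methylphenyl on a carbonyl carbon. The closest measured change, fluoro in place of methyl on an aromatic carbon, is a step that the two limits leave unreadable from compound 1 to compound 2. The other measured steps, an at least 1.1-fold lower number from compound 1 to compound 3 (0.04 log units; that floor lies within the scatter) and an at least 1.1-fold lower number from compound 2 to compound 3 (0.04 log units; that floor lies within the scatter), change a different part of the structure. On this evidence, no change beyond the scatter is expected in this assay, in either direction. The expected result is a 1.0-fold lower number from compound 3 to compound 4 (0.00 log units; within the scatter). For compound 4 the estimated value is 18000 nM, with an expected range from 9000 nM to 36000 nM.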

Compound 4, half-maximal inhibitory concentration: > 20000 nM
Compound 4 gave a limit, no number (the forecaster's own chance of this, stated with the estimate: 45%); middle value at least 1.1-fold (0.04 log units) away from the limit.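

On the carbonyl carbon, 4-fluorophenyl in place of 2-methylphenyl gives an at least 1.1-fold higher number from compound 3 to compound 4 (0.04 log units; that floor lies within the scatter) in this assay, so this swap brings no measurable gain, and the true size of the step stays hidden behind a limit. The steps to compound 4 from compound 1 and from compound 2 cannot be read. The set therefore offers little to compare: the limit of > 20000 nM in this assay, at which 3 of the 4 values shown sit.

As far as these compounds go, it remains open whether an amine or a carboxylic acid in place of the 4-fluorophenyl on that carbonyl carbon would give a clearly lower number.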